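Swapping methoxy for chloro on a second core

The compounds below may be only part of what the source reports. "The series", "measured", "known", "first", "only" and "open" are said of these compounds alone.

Measured compounds:
compound 1, `COc1ccccc1Cc1cc2c(N)nc(-c3ccc(C)o3)nc2s1`, 122 nM
compound 2, `Cc1ccc(-c2nc(N)c3cc(Cc4ccccc4Cl)sc3n2)o1`, 26.1 nM
compound 3, `COc1ccccc1Cc1cc2c(N)nc(-c3nc(C)cs3)nc2s1`, 186 nM

All three were tested in a functional assay on CHO-K1 cells for antagonist activity at adenosine receptor A1 (Homo sapiens), read by a beta-galactosidase reporter and cAMP accumulation, with stated times of 15 min and 6 h; on this read-out higher numbers stand for weaker inhibition and lower numbers for stronger inhibition. Compound 2 differs from compound 1 by one change, (chloro in place of methoxy on an aromatic carbon), and this gave a 4.7-fold lower number from compound 1 to compound 2 (0.67 log units; beyond the scatter). Compound 3 differs from compound 1 in its core: 4-methyl-1,3-thiazol-2-yl in place of 5-methylfuran-2-yl on an aromatic carbon, a step of a 1.5-fold higher number from compound 1 to compound 3 (0.18 log units; within the scatter).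

Compound 4, `Cc1csc(-c2nc(N)c3cc(Cc4ccccc4Cl)sc3n2)n1`, is not yet measured. It differs from compound 3 by chloro in place of methoxy on an aromatic carbon, the same change as between compound 1 and compound 2, and the surroundings of the place are described in the same words for both pairs. The expectation rests on compound 1 and compound 2, whose step was a 4.7-fold lower number from compound 1 to compound 2 (0.67 log units; beyond the scatter); a similar step is expected from compound 3 to compound 4, namely a 4.4-fold lower number from compound 3 to compound 4 (0.65 log units; beyond the scatter). Compound 4 is therefore estimated at 42 nM, between 15 nM and 120 nM.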

Compound 4, inhibition constant: 49.6 nM
Beside the measured number, compound 4's estimate is 1.2-fold (0.07 log units) below it; the range from low to high includes it.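

In this assay, chloro in place of methoxy gave a 3.8-fold lower number from compound 3 to compound 4 (0.57 log units; beyond the scatter), so the change carried from the core of compound 1 to the core of compound 3 at much the same size: the same change on two cores in this assay, a 4.7-fold lower number (0.67 log units; beyond the scatter) from compound 1 to compound 2 and a 3.8-fold lower number (0.57 log units; beyond the scatter) from compound 3 to compound 4, 1.2-fold (0.10 log units) apart, within the scatter of two such steps. Read the other way, 4-methyl-1,3-thiazol-2-yl in place of 5-methylfuran-2-yl gave a 1.9-fold higher number from compound 2 to compound 4 (0.28 log units; within the scatter), which also matches the earlier step: the same change on two cores in this assay, a 1.5-fold higher number (0.18 log units; within the scatter) from compound 1 to compound 3 and a 1.9-fold higher number (0.28 log units; within the scatter) from compound 2 to compound 4, 1.2-fold (0.10 log units) apart, within the scatter of two such steps. For the compounds shown here, these are only two cores and one read-out, so this does not show that the change would carry to any other core, nor why each step has the size it has.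

Still open, from the compounds shown here alone, is whether fluoro, methyl or an amine in the same place would give a step like that of chloro. Also open, going by these compounds, is whether the chloro step would hold with a phenyl in place of 5-methylfuran-2-yl.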